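The source may hold more compounds than are shown below. What is called first, only, known or untested is meant among the compounds shown, and "the series" means these compounds.

In a functional assay on K562 cells (Homo sapiens) for cytotoxicity, read by trypan blue exclusion, with a stated time of 96 h (a higher number here means a weaker inhibitor, a lower number a stronger inhibitor), three compounds with a shared core have been measured. Compound 1 (`COc1cc(OC)c(/C=C/S(=O)(=O)Cc2ccc(OC)c([N+](=O)[O-])c2)c(OC)c1`) gives 2500 nM, compound 2 (`COC(=O)CNc1cc(CS(=O)(=O)/C=C/c2c(OC)cc(OC)cc2OC)ccc1OC`) gives 100 nM, and compound 3 (`COC(=O)C(F)(F)Nc1cc(CS(=O)(=O)/C=C/c2c(OC)cc(OC)cc2OC)ccc1OC`) gives 250 nM. Compound 3 therefore holds the middle place of the three numbers, nearer to compound 2 than to compound 1.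

The next compound, compound 4 (`COC(=O)C(Nc1cc(CS(=O)(=O)/C=C/c2c(OC)cc(OC)cc2OC)ccc1OC)c1ccc(Cl)cc1`), has (4-chlorophenyl)(methoxycarbonyl)methyl in place of difluoro(methoxycarbonyl)methyl on a nitrogen on an aromatic ring.

Going by the values given here, three measured steps bear on this change. The number fell in a 25-fold lower number from compound 1 to compound 2 (1.40 log units; beyond the scatter), a large step, and in a 10-fold lower number from compound 1 to compound 3 (1.00 log units; beyond the scatter), a modest one. Both steps replaced nitro with a group on a nitrogen, and compound 4 also carries such a group, so a number close to those of compound 2 and compound 3 seems more likely than one close to that of compound 1. The most direct guide is a 2.5-fold higher number from compound 2 to compound 3 (0.40 log units; beyond the scatter), a modest step that also changed the group on that nitrogen. Among the compounds with values here, no measured compound has an aromatic ring in this group, so the guide is weak.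

In this assay, a small rise is expected, possibly not beyond the scatter. The expected change is a 1.4-fold higher number from compound 3 to compound 4 (0.15 log units; within the scatter). For compound 4 the estimated value is 350 nM, with an expected range from 90 nM to 1500 nM.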

Compound 4, half-maximal inhibitory concentration: 200 nM
Compound 4: the middle estimate sits 1.8-fold (0.24 log units) above what was measured, and the stated range covers the measured number.
By their numbers in this assay, from the lowest: compounds 2, 4 and 3 (each within the scatter of the next, the first and the last beyond it); then compound 1.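

In this assay, the nitrogen on an aromatic ring can carry (4-chlorophenyl)(methoxycarbonyl)methyl, with 12 heavy atoms and one six-membered aromatic ring, in place of difluoro(methoxycarbonyl)methyl, with 7 heavy atoms and no ring, and the result is a 1.3-fold lower number from compound 3 to compound 4 (0.10 log units; within the scatter). Compared with the simpler (methoxycarbonyl)methyl group, placing 4-chlorophenyl in place of hydrogen on the saturated chain carbon gives a 2.0-fold higher number from compound 2 to compound 4 (0.30 log units; within the scatter), so this position accepts a much larger group with an aromatic ring without a change beyond the scatter, something the earlier compounds, which had no ring in this group, could not show. Nothing measured here accounts for this result.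

From the compounds shown here alone, what remains open is how a plain phenyl or a 4-methoxyphenyl on the same carbon would compare with 4-chlorophenyl, which would show whether the chlorine matters at all. Going by these compounds, it is also open how a carboxylic acid or an amide would behave in place of the methyl ester, which all three of these nitrogen-linked groups share.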